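This account rests on a few compounds, and the source may have more. Where it says the series, first, only, none or still open, it means among the compounds named here.

Compound 1 `O=C(Nc1nc2ccc(Cl)cc2s1)c1cc(-c2ccc(F)cc2)n2nc(-c3ccccc3)cc2n1`: 17600 nM
Compound 2 `COc1ccc(-c2cc(C(=O)Nc3nc4ccc(Cl)cc4s3)nc3cc(-c4ccccc4)nn23)cc1`: 5880 nM
Compound 3 `COc1ccc(-c2cc(C(=O)Nc3nc4ccc(Cl)cc4s3)nc3cc(-c4ccccc4)nn23)cc1OC`: 9330 nM

All three values come from a functional assay on DU-145 cells (Homo sapiens) for cytotoxicity, read by MTT assay, with a stated time of 48 h; a lower number here means a stronger inhibitor, a higher number a weaker inhibitor. Compound 1 gives the highest of the three numbers: the step of a 1.9-fold lower number from compound 1 to compound 3 (0.28 log units; within the scatter) stays within the scatter, while the step of a 3.0-fold lower number from compound 1 to compound 2 (0.48 log units; beyond the scatter) goes beyond it. Compound 4 `O=C(Nc1nc2ccc(F)cc2s1)c1cc(-c2ccc(F)cc2)n2nc(-c3ccccc3)cc2n1` is made from compound 1 by a single change: fluoro in place of chloro on an aromatic carbon. Within the data shown here, none of the measured steps touches this part of the shared core; each of them alters a group elsewhere in the molecule, so no measured step bears directly on this exchange. With nothing pointing either way, compound 4 is expected to stay within the scatter of compound 1, an expected step of a 1.0-fold higher number from compound 1 to compound 4 (0.01 log units; within the scatter) in this assay. The estimate for compound 4 is 18000 nM, with a range from 8000 nM to 40000 nM.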

Compound 4, half-maximal inhibitory concentration: 22900 nM
The estimate for compound 4 lay 1.3-fold (0.10 log units) below the measured number, and the stated range covers the measured number.
By their numbers in this assay, from the lowest: compounds 2, 3, 1 and 4 (each within the scatter of the next, the first and the last beyond it).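

Among these compounds, exchanging 6-chloro-1,3-benzothiazol-2-yl for 6-fluoro-1,3-benzothiazol-2-yl gives the first measured step at this halogen, and in this assay it reads a 1.3-fold higher number from compound 1 to compound 4 (0.11 log units; within the scatter), which lies within the scatter. Chloro and fluoro therefore cannot be told apart at this place, at least alongside the 4-fluorophenyl group that compound 1 and compound 4 share. No measured evidence explains this result.

As far as these compounds go, whether an amine, a nitrile or a carboxylic acid at this place would also leave the number within the scatter remains open. So does whether the same halogen exchange would give a similar step on compound 2, which carries methoxy instead of the fluoro on its phenyl group.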